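Cytotoxicity notes on the amine swap toward compound 4

A few compounds are considered here, and "the series" means these few. Any claim that something is new, unique, unknown or untested is made for them only; others in the source may bear on it.

The series is gauged in an ADME assay on MT4 cells (Homo sapiens) for cytotoxicity, read by MTT assay, with a stated time of 96 h; on this read-out lower numbers stand for higher toxicity in this test and higher numbers for lower toxicity in this test. Compound 1 `CCN(CC)CC(=O)Nc1ccc(-c2nc3cc(C(F)(F)F)ccc3n2C)cc1` gives 9000 nM, the second highest of the three numbers in hand. For the measured compounds named here, its nearest neighbour is compound 3 `CCN(CC)CC(=O)Nc1ccc(-c2nc3cc(C(F)(F)F)ccc3[nH]2)cc1`, which gives 8000 nM; the one step between them reads a 1.1-fold lower number from compound 1 to compound 3 (0.05 log units; within the scatter). Furthest from compound 1 lies compound 2 `O=C(CN1CCCC1)Nc1ccc(-c2nc3ccccc3[nH]2)cc1`, which gives 40000 nM, but it differs from compound 1 and from compound 3 in more than one place, so no single step is drawn to it.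

Compound 4 `Cn1c(-c2ccc(NC(=O)CN3CCCCC3)cc2)nc2cc(C(F)(F)F)ccc21` differs from compound 1 in one place: piperidin-1-yl in place of diethylamino on a saturated chain carbon bound to a carbonyl carbon. Going by the values given here, no measured step touches this part of the molecule. Among the compounds with values here, the only recorded step, from compound 1 to compound 3, concerns the aromatic nitrogen and is small. Compound 2 mixes more than one change against compound 3, so its value gives no clean reading of the amine alone. Nothing in hand argues for a move beyond the scatter. Compound 4 is therefore expected to give 9000 nM. Its range is estimated from 4000 nM to 20000 nM. The expected step is no change at the digits printed from compound 1 to compound 4 (within the scatter).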

Compound 4, half-maximal cytotoxic concentration: 9000 nM
Compound 4: the middle estimate sits on the measured number at the digits printed; the range from low to high includes it.
By their numbers in this assay, from the lowest: compounds 3, 1 and 4 (each within the scatter of the next); then compound 2.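

In this assay, for the compounds shown here, this is the first clean reading of the amine on the saturated chain carbon bound to a carbonyl carbon: piperidin-1-yl in place of diethylamino gives no change at the digits printed from compound 1 to compound 4 (within the scatter). On the core of compound 1, an open-chain amine and a six-membered non-aromatic ring at this position therefore cannot be told apart in this read-out. No measured property of these compounds bears on the result.

Still open, going by these compounds, is whether a ring with a second hetero atom, such as morpholin-4-yl or 4-methylpiperazin-1-yl, would hold the number within the scatter at this position. Also open, on these data alone, is whether piperidin-1-yl would read the same way on the core of compound 3, which has hydrogen on the aromatic nitrogen.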